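The source may report more compounds than this note shows. Statements on the series, on what has been measured and on what is new or still open speak of the compounds shown alone.

Compound 1 `Cc1cc(NC(=O)Cn2nnc(-c3ccccc3)n2)n(C2CCS(=O)(=O)C2)n1`: 93%
Compound 2 `Cc1cc(NC(=O)Cn2nnc(-c3ccc(Cl)c(Cl)c3)n2)n(C2CCCCC2)n1`: 84%

In an assay on HEK293 cells for activation of Kir3.1/Kir3.2 (Homo sapiens), read by thallium flux (on this read-out lower numbers stand for smaller maximal responses and higher numbers for larger maximal responses), compound 2 gives 84% and compound 1 gives 93%; the two values lie within the usual scatter of each other, so compound 2 is not set apart from compound 1 on these numbers. Compound 3 `Cc1ccc(-c2nnn(CC(=O)Nc3cc(C)nn3C3CCCCC3)n2)cc1` is not yet measured. It differs from compound 2 by 4-methylphenyl in place of 3,4-dichlorophenyl on an aromatic carbon. Among the measured compounds shown here, no measured pair shows this kind of change, so a step in this assay of no more than the scatter is expected, in no firm direction. Compound 3 is estimated to give 84%, between 66% and 100%, which means an expected step of no change at the digits printed from compound 2 to compound 3 (within the scatter).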

Compound 3, largest response reached (Emax), in percent of the reference or control that the assay uses: 86%
Estimate against measurement, compound 3: 2 percentage points below; the range from low to high includes it.
By their numbers in this assay, from the lowest: compounds 2, 3 and 1 (each within the scatter of the next).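

In this assay, 4-methylphenyl in place of 3,4-dichlorophenyl on this aromatic carbon gives a number 2 percentage points higher from compound 2 to compound 3 (within the scatter). Among the compounds shown here, this is the first pair that differs in this one place, and it does not set the two substituted phenyl groups apart. Nothing measured here points to a cause for this result. The compounds shown leave open whether a phenyl ring carrying an amine or a carboxylic acid would stay within the scatter at this position. Going by these compounds, a longer chain between the phenyl ring and the aromatic carbon also remains open.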